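Isopropylsulfanyl Gives Way to Sec-Butoxy on the Carbonyl Carbon

The source may hold more compounds than are shown below. What is called first, only, known or untested is meant among the compounds shown, and "the series" means these compounds.

compound 1 `CC(=O)C1=C(C)NC(=O)NC1c1ccsc1`: 24%
compound 2 `CCNC(=O)C1=C(C)NC(=O)NC1c1ccsc1`: 1%
compound 3 `CC1=C(C(=O)SC(C)C)C(c2ccsc2)NC(=O)N1`: 14%

All three compounds were tested in an assay on membranes from HEK293 cells for displacement of a labelled ligand from adenosine receptor A2b (Homo sapiens), read by scintillation counting, with a stated time of 30 min, tested at 1 uM; a higher number here means more inhibition at the concentration tested (going by the name of the read-out), a lower number less inhibition. They share one core and differ only in the group attached to a carbonyl carbon. Compound 3 has the second highest of the three numbers. Its nearest neighbour is compound 1: the step of a number 10 percentage points lower from compound 1 to compound 3 (within the scatter), so these two cannot be told apart. The step of a number 13 percentage points higher from compound 2 to compound 3 (beyond the scatter) sets compound 2 apart from compound 3 by a modest amount.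

Compound 4 `CCC(C)OC(=O)C1=C(C)NC(=O)NC1c1ccsc1` has not yet been measured. The change from compound 3 is sec-butoxy in place of isopropylsulfanyl on a carbonyl carbon. Going by the values given here, no measured step swaps isopropylsulfanyl for sec-butoxy, so the evidence is indirect. The two steps that touch this carbonyl carbon are a number 10 percentage points lower from compound 1 to compound 3 (within the scatter) and a number 13 percentage points higher from compound 2 to compound 3 (beyond the scatter); both are small, and one stays within the scatter. Exchanging one uncharged chain for another of similar size at the same place is therefore expected to produce no step beyond the scatter in this assay, with a slight lean downward. Compound 4 is estimated at 12%, with a range from 0% to 30%. The expected step is a number 2 percentage points lower from compound 3 to compound 4 (within the scatter).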

Compound 4, a percentage reported as inhibition, at one concentration (the size of the read-out at that concentration, not a potency): 39%
Compound 4: middle estimate off by 27 percentage points, on the low side, and the stated range ends below it.
By their numbers in this assay, from the lowest: compound 2; then compounds 3 and 1 (each within the scatter of the next); then compound 4.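

Going by these compounds alone, this position is more sensitive than the earlier compounds suggested. In this assay, sec-butoxy in place of isopropylsulfanyl gives a number 25 percentage points higher from compound 3 to compound 4 (beyond the scatter) even though both groups are uncharged chains without a ring and have the same counts of hydrogen-bond donors and acceptors, so those counts alone do not tell these two groups apart in this assay. Sec-butoxy also clears the other two groups on this carbonyl carbon, with a number 15 percentage points higher from compound 1 to compound 4 (beyond the scatter) and a number 38 percentage points higher from compound 2 to compound 4 (beyond the scatter) in the same direction, which gives compound 4 the highest number of the four, though nothing measured here offers a reason for this rise.

The compounds shown leave open whether the gain goes with the oxygen in place of the sulfur or with the larger chain, a question that isopropoxy or sec-butylsulfanyl on the same carbon could separate. They also leave open how a longer chain such as hexyloxy, or a carboxylic acid, would read at this place, and whether the gain seen at one concentration would hold as a true potency.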